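Lengthening an Alkoxy Chain: From Compound 1 to Compound 4

A few compounds are considered here, and "the series" means these few. Any claim that something is new, unique, unknown or untested is made for them only; others in the source may bear on it.

Of the compounds shown here, three built on a shared core have been measured in a functional assay on KB cells (Homo sapiens) for cytotoxicity, read by MTT assay, with a stated time of 72 h; on this read-out higher numbers stand for weaker inhibition and lower numbers for stronger inhibition. Compound 1 `CCCOCNc1n[n+]([O-])c2cc(OC)ccc2[n+]1[O-]` gives 3200 nM in this assay, the highest of the three numbers. Compound 3 `CCOCNc1n[n+]([O-])c2ccccc2[n+]1[O-]` gives 2800 nM, a figure within the usual scatter of compound 1, so these two cannot be told apart. Compound 2 `O=[N+]([O-])c1cccc(COCNc2n[n+]([O-])c3ccccc3[n+]2[O-])c1`, which carries a larger group on the chain, gives 580 nM, a clearly stronger result than compound 1 and the only gap among the three that lies beyond the scatter.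

Compound 4 `CCCCCOCNc1n[n+]([O-])c2cc(OC)ccc2[n+]1[O-]` has not yet been measured. It differs from compound 1 in one place: ethyl in place of hydrogen on a saturated chain carbon, three bonds along the chain from an oxygen on a saturated carbon. Within the data shown here, no measured pair shows this exact change, so there is no direct step to lean on. Among the measured compounds shown here, the only hint is that compound 2 gives 580 nM in this assay, while compound 1 gives 3200 nM, suggesting that enlarging the group on this chain can lower the number. On that basis the step of a 1.8-fold lower number from compound 1 to compound 4 (0.25 log units; within the scatter) is expected to be a modest improvement in this assay, small enough that it may not clear the scatter. Compound 4 is therefore estimated at 1800 nM, with a likely range from 600 nM to 5000 nM.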

Compound 4, half-maximal inhibitory concentration: 2810 nM
Estimate against measurement, compound 4: 1.6-fold (0.19 log units) below, and the stated range covers the measured number.
By their numbers in this assay, from the lowest: compound 2; then compounds 3, 4 and 1 (each within the scatter of the next).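

In this assay, ethyl in place of hydrogen on a saturated chain carbon, three bonds along the chain from an oxygen on a saturated carbon, gives a 1.1-fold lower number from compound 1 to compound 4 (0.06 log units; within the scatter), so compound 1 and compound 4 cannot be told apart. Among these compounds, this is the first direct reading at this position, which no earlier pair of compounds could give: going from propyl to pentyl on the core of compound 1 leaves the result inside the ordinary noise of the measurement, and so this change offers no sign of a real gain or loss in cytotoxicity. Nothing available bears on why the two compounds read alike.

Still open, as far as these compounds go, is whether a much longer chain, such as octyl, or an amine or a carboxylic acid at the end of the chain would shift the number beyond the scatter. Compound 2 differs from compound 1 in more than one place, so it remains unsettled which of those differences, if any single one, accounts for the gap between them.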